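Replacing dimethylamino with bromo: what to expect

The source may report more compounds than this note shows. Statements on the series, on what has been measured and on what is new or still open speak of the compounds shown alone.

In a functional assay on MCF7 cells (Homo sapiens) for cytotoxicity, read by MTT assay, with a stated time of 72 h (a higher number here means a weaker inhibitor, a lower number a stronger inhibitor), the measured compounds give these values
- compound 1 `CC(C)=C1C(=O)N(c2ccc(Cl)cc2)N(c2ccc(Cl)cc2)C1=O` gives 39600 nM as its value
- compound 2 `CCC(C)=C1C(=O)N(c2ccc(Cl)cc2)N(c2ccc(Cl)cc2)C1=O` gives 41600 nM as its value
- compound 3 `CN(C)c1ccc(C=C2C(=O)N(c3ccc(Cl)cc3)N(c3ccc(Cl)cc3)C2=O)cc1` gives > 128000 nM as a limit of the assay, not a number

For compound 3 there is only the limit of > 128000 nM in this assay, at which 1 of the 3 values shown sits, and no exact number to start from. The step to compound 4 `O=C1C(=Cc2ccc(Br)cc2)C(=O)N(c2ccc(Cl)cc2)N1c1ccc(Cl)cc1` puts bromo in place of dimethylamino on an aromatic carbon, para to a large group, and bromo in place of dimethylamino on an aromatic carbon counts what changes.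

Among the compounds with values here, the only measured step is a 1.1-fold higher number from compound 1 to compound 2 (0.02 log units; within the scatter) and it is a methyl in place of hydrogen on a saturated chain carbon bound to a double-bonded chain carbon. That change lies elsewhere in the structure, so its size says little about this one. Within the data shown here, compound 1 at 39600 nM and compound 2 at 41600 nM share their core with compound 4 and give the only numbers to lean on.

A step in this assay toward that level is therefore expected, to a lower number and so a stronger inhibitor. Compound 4 could also end at a limit of the assay. The expected step is an at least 1.9-fold lower number from compound 3 to compound 4 (0.29 log units; that floor lies within the scatter) as an estimate only. For compound 4 the estimated value is 65000 nM with an expected range from 25000 nM to 128000 nM as the upper end.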

Compound 4, half-maximal inhibitory concentration: 30400 nM
Estimate against measurement, compound 4: 2.1-fold (0.33 log units) above, within the range that was stated.
By their numbers in this assay, from the lowest: compounds 4, 1 and 2 (each within the scatter of the next). At a limit, above all of these: compound 3.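

The earlier step, a 1.1-fold higher number from compound 1 to compound 2 (0.02 log units; within the scatter), lay elsewhere in the structure and said nothing about this position. In this assay, within the data shown here, the aromatic carbon para to a large group does respond to what it carries: bromo in place of dimethylamino gives an at least 4.2-fold lower number from compound 3 to compound 4 (0.62 log units; beyond the scatter), the only step in this set that lies beyond the scatter. That size is a floor and not a measured gap, because compound 3 has only a limit and no exact number: the limit of > 128000 nM in this assay, at which 1 of the 4 values shown sits.

Among these compounds, with only two groups seen at this position, it stays open whether the lower number comes from having bromo there or simply from losing dimethylamino, and a plain hydrogen, a chloro or a methoxy at the same carbon could tell these two readings apart. From the compounds shown here alone, it also stays open whether a carboxylic acid or a primary amine at this carbon would stay near the level of compound 4 at 30400 nM or would move as far away from it as the dimethylamino group of compound 3 does.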